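A few compounds are considered here, and "the series" means these few. Any claim that something is new, unique, unknown or untested is made for them only; others in the source may bear on it.

Of the compounds shown here, two have been measured in a functional assay on MDA-MB-231 cells (Homo sapiens) for cytotoxicity, read by MTT assay, with a stated time of 72 h; a higher number here means a weaker inhibitor, a lower number a stronger inhibitor. Compound 1 `COc1ccc(Cn2ncc3cc(C(=N)Nc4ccccc4)ncc32)cc1` gives 34700 nM there. Compound 2 `Cn1ncc2cc(C(=N)Nc3cccc(C(F)(F)F)c3)ncc21` returns in this assay only > 50000 nM, which is a limit of the assay and not a number. That reading is the limit of > 50000 nM in this assay, at which 1 of the 2 values shown sits. Within the data shown here, compound 2 thus stands at the limit and cannot be placed against the number for compound 1, and the two compounds differ in more than one place, so their values show no single step. Compound 3 `COc1ccc(Cn2ncc3cc(C(=N)Nc4cccc(C(F)(F)F)c4)ncc32)cc1` has not been measured. It differs from compound 2 by 4-methoxyphenyl in place of hydrogen on a saturated chain carbon bound to an aromatic nitrogen. Among the measured compounds shown here, no step between measured compounds covers this change on its own. Compound 1, which also carries the 4-methoxybenzyl group, gives 34700 nM, a number that marks it as a weak inhibitor. The step from compound 2 to compound 3 is estimated as an at least 1.2-fold lower number from compound 2 to compound 3 (0.09 log units; that floor lies within the scatter), a small move toward a stronger inhibitor, not clearly beyond the scatter. Compound 3 is expected at 40000 nM, within 15000 nM to 80000 nM, with a real chance that the assay again reports only a limit.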

Compound 3, half-maximal inhibitory concentration: 29800 nM
Compound 3: middle estimate off by 1.3-fold (0.13 log units), on the high side; the range from low to high includes it.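

In this assay the change of methyl to 4-methoxybenzyl can now be read on its own, and it shows an at least 1.6-fold lower number from compound 2 to compound 3 (0.22 log units; that floor lies within the scatter), so the direction favours the larger group but the floor of the step does not clear the scatter. Among these compounds, the reading for compound 2 is a limit of the assay and not a number, so the step has a floor and no upper bound: the limit of > 50000 nM in this assay, at which 1 of the 3 values shown sits. With the 4-methoxybenzyl group in place, trifluoromethyl in place of hydrogen on an aromatic carbon gives a 1.2-fold lower number from compound 1 to compound 3 (0.07 log units; within the scatter), so the two compounds cannot be told apart in this assay and the added trifluoromethyl shows no measurable step.

On these data alone, the true size of the change from methyl to 4-methoxybenzyl stays open, as does whether the methoxy group on the phenyl ring plays any part in it. Also open, as far as these compounds go, is whether an unsubstituted benzyl group or a longer chain ending in an amine, at the same place on the saturated chain carbon, would shift the number beyond the scatter.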